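From 3-methylphenyl to 2,4-dichlorophenyl

The source may report more compounds than this note shows. Statements on the series, on what has been measured and on what is new or still open speak of the compounds shown alone.

Compounds measured so far in a functional assay on SGC-7901 cells (Homo sapiens) for antiproliferative activity, read by MTT assay, with a stated time of 72 h; on this read-out lower numbers stand for stronger inhibition and higher numbers for weaker inhibition
Compound 1 `COc1ccc(-c2ccc3ncn(-c4cc(OC)c(OC)c(OC)c4)c3c2)cc1O` gives 44 nM
Compound 2 `COc1cc(-n2cnc3ccc(-c4ccc([N+](=O)[O-])cc4)cc32)cc(OC)c1OC` gives 79 nM
Compound 3 `COc1cc(-n2cnc3ccc(-c4cccc(C)c4)cc32)cc(OC)c1OC` gives 1240 nM

Of these three, compound 3 has the highest number and is the weakest inhibitor, as its steps to both other compounds lie beyond the scatter. Compound 4 `COc1cc(-n2cnc3ccc(-c4ccc(Cl)cc4Cl)cc32)cc(OC)c1OC` has yet to be measured and differs from compound 3 at one place on the shared core (2,4-dichlorophenyl in place of 3-methylphenyl on an aromatic carbon), where 2,4-dichlorophenyl stands in place of 3-methylphenyl on an aromatic carbon.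

Among the compounds with values here, three measured steps concern this same place. Two of them (a 28-fold higher number from compound 1 to compound 3 (1.45 log units; beyond the scatter)) and (a 16-fold higher number from compound 2 to compound 3 (1.20 log units; beyond the scatter)) are large, showing that a change of group here can move the number far. The third (a 1.8-fold higher number from compound 1 to compound 2 (0.25 log units; within the scatter)) stays within the scatter. Within the data shown here, no measured compound carries chlorine, so the entering group has no direct precedent. Compound 3 at 1240 nM sits at the top of the range, and the other two groups both gave lower numbers, so a moderate move to a lower number is expected in this assay, though with wide uncertainty. The estimated step is (a 2.5-fold lower number from compound 3 to compound 4 (0.39 log units; beyond the scatter)). The estimate for compound 4 is 500 nM (expected range 90 nM to 2500 nM).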

Compound 4, half-maximal inhibitory concentration: > 10000 nM
Compound 4: only a limit was reported (the forecaster's own chance of this, stated with the estimate: 3%); middle value at least 20-fold (1.30 log units) from the limit.
By their numbers in this assay, from the lowest: compounds 1 and 2 (each within the scatter of the next); then compound 3. At a limit, above all of these: compound 4.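

In this assay compound 4 is reported only as a limit, > 10000 nM, and this position proves able to lose activity beyond the range the earlier compounds had marked out: the limit of > 10000 nM in this assay, at which 1 of the 4 values shown sits.

The change of 3-methylphenyl to 2,4-dichlorophenyl gives an at least 8.0-fold higher number from compound 3 to compound 4 (0.90 log units; beyond the scatter), even though both groups are a single six-membered aromatic ring of carbon only with no hydrogen-bond donors or acceptors counted, which shows that these shared counts do not fix the number at this place. Set against the two groups with the lowest numbers, the entering group gives an at least 120-fold higher number from compound 2 to compound 4 (2.10 log units; beyond the scatter) and an at least 220-fold higher number from compound 1 to compound 4 (2.35 log units; beyond the scatter), both wider than any step among the earlier compounds at this position.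

The compounds shown leave open whether a phenyl ring carrying a single chlorine would stay near compound 3 or share the limit of compound 4, and so whether one chlorine or the pair matters. They also leave open how a phenyl ring carrying an amine would compare at this place with the 3-hydroxy-4-methoxyphenyl of compound 1 and the 4-nitrophenyl of compound 2.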